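The compounds below may be only part of what the source reports. "The series", "measured", "known", "first", "only" and "open" are said of these compounds alone.

Compound 1 `O=[N+]([O-])c1ccc(-c2cn3nc(Cc4ccc(Cl)cc4)sc3n2)cc1`: > 250000 nM
Compound 2 `O=c1oc2ccccc2cc1-c1cn2nc(Cc3ccc(Cl)cc3)sc2n1`: > 10000 nM
Compound 3 `Clc1ccc(Cc2nn3c(Br)c(-c4ccc(Cl)cc4)nc3s2)cc1`: > 250000 nM

All three compounds were tested in an ADME assay on CCRF-CEM cells (Homo sapiens) for cytotoxicity, with a stated time of 72 h; a lower number here means a stronger inhibitor, a higher number a weaker inhibitor. The value of compound 1 is a limit of the assay, not a number. The value of compound 2 is also a limit. Compound 3, with > 250000 nM, stands at a limit as well. Two of the three values shown sit at the limit of > 250000 nM in this assay, at which 2 of the 3 values shown sit, while the remaining value sits at the limit of > 10000 nM in this assay, at which 1 of the 3 values shown sits. Within the data shown here, because none of these values is a number, no step between measured compounds can be given, and no pair of them can be ordered.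

Compound 4 `Clc1ccc(Cc2nn3c(Br)c(-c4ccccc4)nc3s2)cc1` is the next compound to be measured in this assay. It differs from compound 3 in one place: hydrogen in place of chloro on an aromatic carbon, a hydrogen in place of chloro on an aromatic carbon. Nothing measured here shows what such a change does in this assay, so no direction or size can be taken from the data. The expected step from compound 3 to compound 4 is therefore set to none beyond the scatter, a number no higher from compound 3 to compound 4 (the limit leaves the size open). Compound 4 is expected to give about 250000 nM in this assay, with a range from 60000 nM to 1000000 nM, and most likely the assay will again report only a limit.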

Compound 4, half-maximal inhibitory concentration: > 250000 nM
Compound 4 was reported as a limit; the forecaster's own chance of this, stated with the estimate: 75%; the middle value sits exactly at the limit.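

In this assay, among these compounds, compound 3 and compound 4 are both reported only as limits, not as numbers, and no step between compound 3 and compound 4 can be read. The compounds shown leave open whether changing 4-chlorophenyl to phenyl alters the result at all, and how strongly any of these compounds inhibits the cells.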